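The source may report more compounds than this note shows. Statements on the series, on what has been measured and on what is new or still open speak of the compounds shown alone.

Measured so far in a functional assay on MDA-MB-468 cells (Homo sapiens) for antiproliferative activity, read by MTT assay, with a stated time of 72 h; on this read-out lower numbers stand for stronger inhibition and higher numbers for weaker inhibition:
- Compound 1 `CCn1ccnc1-c1cc(OC)c(OC)c(OC)c1`: > 100000 nM, a limit
- Compound 2 `COc1cc(-c2nccn2CC(C)C)cc(OC)c1OC`: > 100000 nM, a limit

Compound 1 has no number on this read-out, only a limit: in this assay compound 1 gives > 100000 nM. The record so far is the limit of > 100000 nM in this assay, at which 2 of the 2 values shown sit.

The next compound is compound 3 `COc1cc(-c2nccn2Cc2ccccc2)cc(OC)c1OC`. The change from compound 1 is phenyl in place of methyl on a saturated chain carbon bound to an aromatic nitrogen. Cut one bond further out, it reads ethyl to benzyl.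

Going by the values given here, only one measured step bears on this, and it sits at the same place: a step that the two limits leave unreadable from compound 1 to compound 2. Its size cannot be read, since both ends are limits, so it offers no size or direction to carry over to phenyl. Among the compounds with values here, the data therefore support no firm step in this assay. Compound 3 may well stay at the limit, and a measured number could only come out on the stronger side of it, so the expectation leans weakly that way. The expected step, an at least 3.3-fold lower number from compound 1 to compound 3 (0.52 log units; beyond the scatter), is only a rough estimate. For compound 3 the estimated value is 30000 nM, with an expected range of 1000 nM to 150000 nM.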

Compound 3, half-maximal inhibitory concentration: > 100000 nM
Compound 3 gave a limit, no number (the forecaster's own chance of this, stated with the estimate: 50%); at least 3.3-fold (0.52 log units) between middle value and limit.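

Compound 3 gives > 100000 nM in this assay as a limit and not a number, so no new step can be read among compound 1, compound 2 and compound 3: the limit of > 100000 nM in this assay, at which 3 of the 3 values shown sit.

The compounds shown leave open whether any group on the saturated chain carbon bound to the aromatic nitrogen would give a measurable number in this assay on the shared core.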